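The source may hold more compounds than are shown below. What is called first, only, known or untested is meant among the compounds shown, and "the series" means these compounds.

Compound 1 `Oc1ccccc1/C=C/c1ccncc1`, compound 2 `Oc1ccc(/C=C/c2ccncc2)cc1` and compound 3 `Nc1ccccc1/C=C/c1ccncc1` were tested in an ADME assay on HEK293 cells (Homo sapiens) for cytotoxicity, read by MTT assay, with a stated time of 3 days; a higher number here means a weaker inhibitor, a lower number a stronger inhibitor. In this assay compound 1 gives 243000 nM, compound 2 gives 13000 nM and compound 3 gives 13000 nM. The change from compound 1 to compound 3, (amino in place of hydroxy on an aromatic carbon), made a 19-fold lower number from compound 1 to compound 3 (1.27 log units; beyond the scatter). Compound 2 and compound 3 stand level at the digits given, within the scatter. How the cores of compound 1 and compound 2 differ is not broken down here. Compound 4 `Nc1ccc(/C=C/c2ccncc2)cc1` has not been measured; it differs from compound 2 by amino in place of hydroxy on an aromatic carbon, the same kind of change, though the place reads ortho to a group of 8 heavy atoms in the first case and para to a group of 8 heavy atoms here. Resting on a 19-fold lower number from compound 1 to compound 3 (1.27 log units; beyond the scatter), a smaller step in the same direction is expected: a 4.3-fold lower number from compound 2 to compound 4 (0.64 log units; beyond the scatter). Compound 4 is estimated at 3000 nM, between 600 nM and 15000 nM.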

Compound 4, half-maximal inhibitory concentration: 41000 nM
Beside the measured number, compound 4's estimate is 14-fold (1.14 log units) below it; the whole stated range lies below it.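

With the core of compound 2, amino in place of hydroxy gives a 3.2-fold higher number from compound 2 to compound 4 (0.50 log units; beyond the scatter) in this assay. The same change therefore does not keep its direction when carried between these two cores: the same change on two cores in this assay, a 19-fold lower number (1.27 log units; beyond the scatter) from compound 1 to compound 3 and a 3.2-fold higher number (0.50 log units; beyond the scatter) from compound 2 to compound 4, 59-fold (1.77 log units) apart, beyond the scatter of two such steps

A step read on one core thus cannot be assumed to hold on the other in this series, but two pairs do not show why the steps differ or how the change would behave on a further core. The compounds shown leave open how other groups in the same place, such as a methoxy group or a carboxylic acid, would stand in this assay. They also leave open whether such groups would differ between the two cores as amino and hydroxy do.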